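Aryl variation on the shared core: compound 3

A few compounds are considered here, and "the series" means these few. Any claim that something is new, unique, unknown or untested is made for them only; others in the source may bear on it.

compound 1 `COc1ccc(-c2c(C3=NN(C(=O)CCC(=O)O)C(c4ccc(Cl)cc4)C3)c(=O)[nH]c3ccccc23)cc1` — 2300 nM
compound 2 `O=C(O)CCC(=O)N1N=C(c2c(-c3ccc(C(F)(F)F)cc3)c3ccccc3[nH]c2=O)CC1c1ccc(Cl)cc1` — 2800 nM

Going by the values given here, in an assay on cells (Oocyte) for negative allosteric modulation of glutamate receptor ionotropic, NMDA 2D (Rattus norvegicus), read by two-electrode voltage clamp (a higher number here means a weaker inhibitor, a lower number a stronger inhibitor), compound 2 holds the highest of the two numbers so far; compound 1 is its nearest neighbour and sits within the scatter, as a 1.2-fold higher number from compound 1 to compound 2 (0.09 log units; within the scatter) shows. Compound 3 `Cc1cccc(-c2c(C3=NN(C(=O)CCC(=O)O)C(c4ccc(Cl)cc4)C3)c(=O)[nH]c3ccccc23)c1` differs from compound 2 in one place: 3-methylphenyl in place of 4-(trifluoromethyl)phenyl on an aromatic carbon. Among the compounds with values here, the only measured step, a 1.2-fold higher number from compound 1 to compound 2 (0.09 log units; within the scatter), likewise exchanged one group on an aromatic carbon and moved the number only within the scatter, so no step beyond the scatter is expected in this assay. Compound 3 is therefore estimated at 2500 nM (range 1000 nM to 6500 nM), an expected step of a 1.1-fold lower number from compound 2 to compound 3 (0.05 log units; within the scatter).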

Compound 3, half-maximal inhibitory concentration: 1900 nM
For compound 3 the middle estimate is 1.3-fold (0.12 log units) above the measured one; the measured number falls inside the stated range.
By their numbers in this assay, from the lowest: compounds 3, 1 and 2 (each within the scatter of the next).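

Unlike 4-methoxyphenyl and 4-(trifluoromethyl)phenyl, 3-methylphenyl changes where the substituent sits on the phenyl ring as well as what it is. Even so, in this assay the result is a 1.5-fold lower number from compound 2 to compound 3 (0.17 log units; within the scatter) and a 1.2-fold lower number from compound 1 to compound 3 (0.08 log units; within the scatter), so all three aryl groups on this aromatic carbon remain within the scatter of one another. No evidence bears on the reason for this.

Still open, as far as these compounds go, is whether a phenyl ring carrying an amine or a carboxylic acid, or a cyclohexyl group in place of the phenyl ring, would give a step beyond the scatter.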